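Extending a Sulfonyl Alkyl Group in Pancreatic Cancer Cells

The source may hold more compounds than are shown below. What is called first, only, known or untested is meant among the compounds shown, and "the series" means these compounds.

Three measured compounds set the scene in a functional assay on MIA PaCa-2 cells (Homo sapiens) for inhibition, read by MTT assay, with a stated time of 7 days; on this read-out lower numbers stand for stronger inhibition and higher numbers for weaker inhibition. Compound 1, `CC(C)c1noc(N2CCN(C(=O)[C@@H]3CCCN(S(=O)(=O)c4ccc(S(=O)(=O)C(C)C)cc4)C3)CC2)n1`, gives 70 nM in this assay, the lowest of the three numbers. Compound 2, `CCN(CC)S(=O)(=O)c1ccc(S(=O)(=O)N2CCC[C@@H](C(=O)NC3CN(C(=O)C4CC4)C3)C2)cc1`, gives 2800 nM in this assay, a gap from compound 1 that lies well beyond the usual scatter. Compound 3, `CCOC(=O)[C@H]1CCN(S(=O)(=O)c2ccc(S(=O)(=O)N(CC)CC)cc2)C1`, gives 29200 nM in this assay, further still from compound 1. Compound 1 is therefore the most potent of the three.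

Compound 4, `CCC(CC)S(=O)(=O)c1ccc(S(=O)(=O)N2CCC[C@@H](C(=O)N3CCN(c4nc(C(C)C)no4)CC3)C2)cc1`, differs from compound 1 in one place: pentan-3-yl in place of isopropyl on a sulfonyl sulfur. The entering group is larger but, like the leaving one, carries no hydrogen-bond donor or acceptor and no charge. For the measured compounds named here, no measured pair shows this kind of change, so the expectation rests on compound 1 alone. The step of a 1.2-fold higher number from compound 1 to compound 4 (0.08 log units; within the scatter) is expected to be small, not beyond the scatter, in either direction. Compound 4 is expected to give about 85 nM in this assay, with a likely range from 30 nM to 250 nM.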

Compound 4, half-maximal inhibitory concentration: 50 nM
Compound 4: middle estimate off by 1.7-fold (0.23 log units), on the high side, within the range that was stated.
By their numbers in this assay, from the lowest: compounds 4 and 1 (each within the scatter of the next); then compound 2; then compound 3.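

In this assay, putting pentan-3-yl in place of isopropyl on the sulfonyl sulfur gives ((a 1.4-fold lower number from compound 1 to compound 4 (0.15 log units; within the scatter))), so this pair cannot be told apart. For the compounds shown here, this is the first direct test of this position, and it shows that the larger pentan-3-yl group, which like isopropyl has no ring, hydrogen-bond donors, hydrogen-bond acceptors or net charge, keeps the number in the same range as that of compound 1. No supporting measurement accounts for this result.

The compounds shown leave open whether the same sulfonyl sulfur would accept a longer unbranched chain such as n-octyl, or a ring such as cyclohexyl, with the rest of the structure unchanged. They also leave open what an amine or a carboxylic acid at the end of such a chain would do to the number.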